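The source may hold more compounds than are shown below. What is called first, only, known or untested is meant among the compounds shown, and "the series" means these compounds.

In an assay on mitochondria from L6 cells (Rattus norvegicus) for activation, with a stated time of 90 min (a lower number here means that less compound is needed, a higher number that more compound is needed for the effect), compound 3 `COc1ccc(Nc2nc3nonc3nc2Nc2ccc(OC)cc2)cc1` gives only a limit, > 100000 nM, and so stands at the weak end of the three measured values. Compound 1 `Fc1cc(C(F)(F)F)ccc1Nc1nc2nonc2nc1Nc1ccc(C(F)(F)F)cc1F` also gives a limit, < 1000 nM. For the measured compounds named here, compound 2 `C1CCC(Nc2nc3nonc3nc2NC2CCCC2)C1` is the only one with a number, 45000 nM in this assay. Compound 4 `COc1ccc(Nc2nc3nonc3nc2Nc2ccccc2F)cc1` differs from compound 3 in one place: 2-fluorophenyl in place of 4-methoxyphenyl on a nitrogen on an aromatic ring. Fluorine on a phenyl ring is also what compound 1 carries. Going by the values given here, no measured step in this assay matches this change, so the expectation rests on the gap between compound 1 and compound 3 alone. Among the compounds with values here, the change touches only one of the two rings, so a gain smaller than that whole gap, yet beyond the usual scatter, is expected, an at least 3.3-fold lower number from compound 3 to compound 4 (0.52 log units; beyond the scatter). Compound 4 is estimated at 30000 nM, with a likely range from 6000 nM to 100000 nM.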

Compound 4, half-maximal effective concentration: 1600 nM
Compound 4: the middle estimate sits 19-fold (1.27 log units) above what was measured; measured number below the stated range.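

Replacing 4-methoxyphenyl with 2-fluorophenyl on just one nitrogen gives an at least 62-fold lower number from compound 3 to compound 4 (1.79 log units; beyond the scatter) in this assay. For the compounds shown here, a change on one ring alone is therefore enough for a large gain, which the earlier compounds could not show, as they differ from each other on both sides. This step is only a minimum, because compound 3 gives a limit rather than a number: the limit of > 100000 nM in this assay, at which 1 of the 4 values shown sits.

The compounds shown do not separate the loss of the methoxy group from the gain of the fluorine. From the compounds shown here alone, how an amine or a carboxylic acid on this ring would read also stays open.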